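A few compounds are considered here, and "the series" means these few. Any claim that something is new, unique, unknown or untested is made for them only; others in the source may bear on it.

Working notes on a small set tested in a functional assay on KB cells (Homo sapiens) for antiproliferative activity; a higher number here means a weaker inhibitor, a lower number a stronger inhibitor. Compound 1 `c1ccc(CSc2nc3cnsc3[nH]2)cc1` gives 200 nM in this assay. Compound 2 `CSc1nc2cnsc2n1[C@H]1C[C@H](O)[C@@H](CO)O1` reaches only a limit of this assay, > 100000 nM. Compound 3 `Cc1nsc2c1nc(SCc1ccccc1)n2[C@H]1C[C@H](O)[C@@H](CO)O1` likewise returns a limit, > 100000 nM, so it stands at the limit of > 100000 nM in this assay, at which 2 of the 3 values shown sit, with no number of its own. The step to compound 4 `OC[C@H]1O[C@@H](n2c(SCc3ccccc3)nc3cnsc32)C[C@@H]1O` is hydrogen in place of methyl on an aromatic carbon. Within the data shown here, no measured pair in the set isolates this change. Compound 2 and compound 3 share a portion absent from compound 1, and compound 4 keeps it, so the methyl is not what sets the three measured compounds apart. For compound 4 the expected step is an at least 1.4-fold lower number from compound 3 to compound 4 (0.15 log units; that floor lies within the scatter), nothing beyond the scatter, most likely still a limit. Compound 4 is estimated at 70000 nM, in a range from 3000 nM to 300000 nM.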

Compound 4, half-maximal inhibitory concentration: > 100000 nM
Compound 4: a limit, no number; the forecaster's own chance of this, stated with the estimate: 70%; middle value at least 1.4-fold (0.15 log units) from the limit.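

In this assay compound 4 returns > 100000 nM, a limit and not a number. The steps to compound 4 from compound 3 and from compound 2 cannot be read, so hydrogen in place of methyl on this aromatic carbon has no measurable size here. Placing 4-hydroxy-5-(hydroxymethyl)oxolan-2-yl in place of hydrogen on the aromatic nitrogen gives an at least 500-fold higher number from compound 1 to compound 4 (2.69 log units; beyond the scatter).

With that group present, the values give no reading of the aromatic carbon: the limit of > 100000 nM in this assay, at which 3 of the 4 values shown sit. Open is what methyl or an amine on this carbon would do in compound 1, which keeps hydrogen there.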